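The source may report more compounds than this note shows. Statements on the series, on what has been measured and on what is new or still open speak of the compounds shown alone.

Working notes on the series.

Compound 1 `CCOc1ccccc1N1CCN(CC(O)COc2cc3c(cc2OC)COC(C)C3=O)CC1` is measured in an assay on isolated protein (strain SPF) for antagonist activity at Alpha-1D adrenergic receptor (Rattus norvegicus) (on this read-out lower numbers stand for tighter binding and higher numbers for weaker binding), and gives 485 nM; of the two numbers recorded so far this is the highest. For the measured compounds named here, compound 2 `COc1cc2c(cc1OCC(O)CN1CCN(C(=O)C3CCCO3)CC1)C(=O)C(C)OC2` gives 195 nM in this assay, and the change a 2.5-fold lower number from compound 1 to compound 2 (0.40 log units; beyond the scatter) is the only measured step in the set.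

Compound 3 `COc1cc2c(cc1OCC(O)CN1CCN(C(=O)c3ccco3)CC1)C(=O)C(C)OC2` is not yet measured. Its difference from compound 1 is (furan-2-yl)carbonyl in place of 2-ethoxyphenyl on an amine nitrogen in a ring. Going by the values given here, the one measured step that bears on it is the exchange of the same 2-ethoxyphenyl on the same ring nitrogen for (oxolan-2-yl)carbonyl, which gave a 2.5-fold lower number from compound 1 to compound 2 (0.40 log units; beyond the scatter). Compound 3 carries a (furan-2-yl)carbonyl at that position, again a carbonyl joined to a five-membered ring, so a step of similar size and direction is expected in this assay: the estimate for compound 3 is a 2.3-fold lower number from compound 1 to compound 3 (0.36 log units; beyond the scatter). Compound 3 is thus estimated at 210 nM, with a range from 80 nM to 550 nM.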

Compound 3, dissociation constant: 1550 nM
For compound 3 the middle estimate is 7.4-fold (0.87 log units) below the measured one; measured number above the stated range.
By their numbers in this assay, from the lowest: compound 2; then compound 1; then compound 3.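

At the amine nitrogen in the ring, a carbonyl joined to a five-membered ring does not by itself fix the direction of the change in this assay: the exchange of 2-ethoxyphenyl for (furan-2-yl)carbonyl gives weaker binding (a 3.2-fold higher number from compound 1 to compound 3 (0.50 log units; beyond the scatter)), whereas the exchange for (oxolan-2-yl)carbonyl gives tighter binding (a 2.5-fold lower number from compound 1 to compound 2 (0.40 log units; beyond the scatter)). The ring on the carbonyl carbon therefore matters, since furan-2-yl in place of oxolan-2-yl alone gives a step beyond the scatter (a 7.9-fold higher number from compound 2 to compound 3 (0.90 log units; beyond the scatter)). Nothing available accounts for this difference between the two rings.

As far as these compounds go, it remains open whether the weaker binding belongs to furan-2-yl alone or extends to other aromatic rings on the same carbonyl, such as thiophen-2-yl or phenyl. From the compounds shown here alone, it is equally open whether a saturated ring such as cyclopentyl or oxan-2-yl would keep the tighter binding of compound 2 (195 nM).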